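The source may report more compounds than this note shows. Statements on the series, on what has been measured and on what is new or still open speak of the compounds shown alone.

Measured in an ADME assay on microsomes from liver (Mus musculus) for metabolic stability, with a stated time of 30 min; a lower number here means that less of the compound is left, a higher number that more of the compound is left:
compound 1 `CCn1c(=O)/c(=C2\Sc3cccc(F)c3N2C)s/c1=C\c1ccccn1`, 12%
compound 2 `CCn1c(=O)/c(=C2\Sc3ccc(F)cc3N2C)s/c1=C\c1ccccn1`, 19%
compound 3 `CCn1c(=O)/c(=C2\Sc3cccc(Cl)c3N2C)s/c1=C\c1ccccn1`, 38%

In this assay compound 1 stands at the low end of the three: the number for compound 2 lies within the usual scatter of it, while compound 3 lies beyond it. Within the data shown here, the only step that has been measured, a number 26 percentage points higher from compound 1 to compound 3 (beyond the scatter), concerns chloro in place of fluoro on an aromatic carbon and so does not touch the part of the molecule changed here.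

Compound 4 `CCn1c(=O)/c(=C2\Sc3cccc(F)c3N2C)s/c1=C\c1ccncc1` differs from compound 1 by pyridin-4-yl in place of pyridin-2-yl on a double-bonded chain carbon bound to an aromatic carbon. Among the measured compounds shown here, no measured compound varies this ring, so there is nothing among the three that bears directly on the change; only the width of the scatter itself guides the expectation. Compound 4 is therefore expected to give about 15%, in the range 5% to 32%. The estimated step of a number 3 percentage points higher from compound 1 to compound 4 (within the scatter) is expected to stay within the scatter.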

Compound 4, percent of the compound remaining: 33%
For compound 4 the middle estimate is 18 percentage points below the measured one; measured number outside the range, above it.
By their numbers in this assay, from the lowest: compounds 1 and 2 (each within the scatter of the next); then compounds 4 and 3 (each within the scatter of the next).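

In this assay, putting pyridin-4-yl in place of pyridin-2-yl gives a number 21 percentage points higher from compound 1 to compound 4 (beyond the scatter), so the ring on the double-bonded chain carbon is a part of the molecule where this read-out can move. The two groups match in heavy atoms, ring size, hydrogen-bond donors, hydrogen-bond acceptors and charge, and differ only in how the same atoms are joined, so a change of that kind is enough to take the number beyond the scatter at this place. Nothing available accounts for the step or identifies what lies behind it.

Still open, from the compounds shown here alone, is how pyridin-3-yl, a plain phenyl ring or a ring carrying an amine would behave on this chain carbon. Going by these compounds, it is also open whether pyridin-4-yl would give a step of similar size on the core of compound 2 or compound 3.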